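Half-life of compound 1 and its chloro counterpart

This account rests on a few compounds, and the source may have more. Where it says the series, first, only, none or still open, it means among the compounds named here.

- compound 1 `C=C(C(=O)Nc1ccccc1)C(F)(F)F`: 0.25 h
- compound 2 `C=C(Cc1ccccc1)C(=O)Nc1ccccc1`: > 8.53 h
- compound 3 `CN1CCN(C/C=C/C(=O)Nc2ccccc2)CC1`: > 8.53 h

All three compounds were measured in an ADME assay for pharmacokinetics, read by LC-MS, in phosphate buffer, with a stated time of 120 min, at pH 7.4, tested at 1 uM, in the presence of a further agent that is not named here; on this read-out lower numbers stand for a shorter-lived compound and higher numbers for a longer-lived compound. Compound 1 is the only one of them with a true number, so it is the natural point of reference. The entry for compound 2 is a limit of the assay and not a number. The entry for compound 3 is likewise a limit.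

The next compound to be measured is compound 4 `C=C(Cl)C(=O)Nc1ccccc1`, which differs from compound 1 at a single place: chloro in place of trifluoromethyl on a double-bonded chain carbon bound to a carbonyl carbon. In words, it carries chloro in place of trifluoromethyl on a double-bonded chain carbon bound to a carbonyl carbon. Going by the values given here, no pair of measured compounds differs in one place only, so the data offer no direct precedent for the size of this change.

The expectation therefore starts from compound 1 with its 0.25 h. A moderate move towards a longer half-life is expected, although a result within the usual scatter of compound 1 would not be surprising. The expected step is a 3.2-fold higher number from compound 1 to compound 4 (0.51 log units; beyond the scatter). For compound 4 the estimated half-life is 0.8 h, with an expected range of 0.2 h to 4 h.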

Compound 4, half-life: 0.05 h
Compound 4: the middle estimate sits 16-fold (1.20 log units) above what was measured, outside the stated range (below it).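

Chloro in place of trifluoromethyl on a double-bonded chain carbon bound to a carbonyl carbon gives, in this assay, a 5.0-fold lower number from compound 1 to compound 4 (0.70 log units; beyond the scatter). Going by these compounds alone, this is the first direct comparison, and it shows that the half-life of the shared core depends on the group at this place, since a single exchange moves it beyond the usual scatter. Of the two groups compared here, trifluoromethyl goes with the longer half-life and chloro with the shorter, so trifluoromethyl is the better of the pair on this read-out, while the data offer no measured property that would explain why the step runs this way.

What the compounds shown leave open is how other groups at this place would rank against chloro and trifluoromethyl, for example a nitrile, a methyl group or a short chain carrying an amine. As far as these compounds go, it also remains open whether the same exchange would give a step of similar size and direction on a core other than that of compound 1.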